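Fluoro on the fused ring with the pyridin-4-yl arm

The compounds below may be only part of what the source reports. "The series", "measured", "known", "first", "only" and "open" are said of these compounds alone.

Measured so far:
- compound 1, `CCn1c(=O)/c(=C2\Sc3cccc(F)c3N2C)s/c1=C\c1ccccn1`: 12%
- compound 2, `CCn1c(=O)/c(=C2\Sc3cc(F)ccc3N2C)s/c1=C\c1ccccn1`: 5%
- compound 3, `CCn1c(=O)/c(=C2\Sc3ccccc3N2C)s/c1=C\c1ccncc1`: 6%

In an ADME assay on microsomes from liver (Mus musculus) for metabolic stability, with a stated time of 30 min (on this read-out higher numbers stand for a more stable compound and lower numbers for a less stable compound), compound 3 gives 6%. Its value lies within the usual scatter of both compound 2 and compound 1, so the three numbers cannot be ordered against each other; all three sit low on this assay.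

Compound 4, `CCn1c(=O)/c(=C2\Sc3cccc(F)c3N2C)s/c1=C\c1ccncc1`, has not been measured. It differs from compound 3 by fluoro in place of hydrogen on an aromatic carbon. Among the measured compounds shown here, no step between measured compounds isolates this change. Compound 1 carries the same fluoro with a different pyridyl arm and gives 12%, which does not separate from compound 3 beyond the scatter.

Compound 4 is therefore expected to give 9% (3% to 18%), an expected step of a number 3 percentage points higher from compound 3 to compound 4 (within the scatter) that stays within the scatter.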

Compound 4, percent of the compound remaining: 33%
Compound 4: middle estimate off by 24 percentage points, on the low side; measured number above the stated range.
By their numbers in this assay, from the lowest: compounds 2, 3 and 1 (each within the scatter of the next); then compound 4.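

In this assay, fluoro in place of hydrogen on this aromatic carbon gives a number 27 percentage points higher from compound 3 to compound 4 (beyond the scatter) and is the only step shown that isolates this change. With that fluoro held in place, pyridin-4-yl in place of pyridin-2-yl gives a number 21 percentage points higher from compound 1 to compound 4 (beyond the scatter) and so the arm also matters, with compound 4 alone combining the two features. Nothing available explains either step.

Going by these compounds, whether the fluoro step also holds with the pyridin-2-yl arm remains open. So does whether chloro, methoxy or a nitrile on the same carbon would give a similar step.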